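Chloro for fluoro: expected cell tolerance of compound 4

The source may hold more compounds than are shown below. What is called first, only, known or untested is meant among the compounds shown, and "the series" means these compounds.

Compound 1 `Nc1nc(-c2ccc(F)cc2)cc(-c2ccc(C3NC(=O)c4ccccc4N3)cc2)n1` has no reported number in an ADME assay on J774.A1 cells (Mus musculus) for cytotoxicity, read by MTT assay, with a stated time of 72 h; a higher number here means that more compound is tolerated, a lower number that less compound is tolerated; its entry reads "not determined" (no result reported). Two related compounds were measured in this assay. Compound 2 `CCCNc1nc(NCCC)nc(Nc2ccc(C3(C)NC(=O)c4ccccc4N3)cc2)n1` gives > 400000 nM, which is a limit of the assay rather than a number. Compound 3 `CC1(c2ccc(NC(c3ccc(Cl)cc3)c3nnnn3C3CCCCC3)cc2)NC(=O)c2ccccc2N1` gives > 400000 nM, again a limit. Both therefore sit at the limit of > 400000 nM in this assay, at which 2 of the 3 values shown sit. Compound 4 `Nc1nc(-c2ccc(Cl)cc2)cc(-c2ccc(C3NC(=O)c4ccccc4N3)cc2)n1` differs from compound 1 by chloro in place of fluoro on an aromatic carbon. Among the compounds with values here, no step between measured compounds is available, so the author expects no step beyond the scatter in this assay; that expectation rests on compounds 2 and 3, which both stand at the limit of > 400000 nM in this assay, at which 2 of the 3 values shown sit. Compound 4 is accordingly estimated at about 300000 nM in this assay, with a range from 80000 nM to 800000 nM, and may well be reported only as a limit.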

Compound 4, half-maximal cytotoxic concentration: 82200 nM
Compound 4: middle estimate off by 3.6-fold (0.56 log units), on the high side; the range from low to high includes it.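

No step can be read from compound 1 to compound 4 in this assay, where compound 1 stands as "not determined" (no result reported). The compounds shown leave open how the change from 4-fluorophenyl to 4-chlorophenyl itself bears on cell tolerance.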